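A few compounds are considered here, and "the series" means these few. Any claim that something is new, unique, unknown or untested is made for them only; others in the source may bear on it.

Of the compounds shown here, three built on one shared core have been tested in an ADME assay on Akata cells (Homo sapiens) for cytotoxicity, with a stated time of 7 days; a higher number here means that more compound is tolerated, a lower number that less compound is tolerated. In this assay compound 1 `CCCCCCCCOc1nc(N)nc2c1ncn2/C=C1/CC1(CO)CO` gives > 20000 nM, which is a limit of the assay and not a number. Compound 2 `CCCOc1nc(N)nc2c1ncn2/C=C1/CC1(CO)CO` gives > 20000 nM, again a limit. Compound 3 `Nc1nc(NCc2ccccc2)c2ncn(/C=C3/CC3(CO)CO)c2n1` gives > 24000 nM, also a limit. Going by the values given here, compound 3 therefore stands where every compound measured so far stands: at a limit, with the two other values also limits, so nothing separates it from the others.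

The change from compound 3 to compound 4 `CCCCCOc1nc(N)nc2c1ncn2/C=C1/CC1(CO)CO` is pentyloxy in place of benzylamino on an aromatic carbon. Among the compounds with values here, three measured steps bear on it loosely: a step that the two limits leave unreadable from compound 1 to compound 3 and a step that the two limits leave unreadable from compound 2 to compound 3 exchange the same benzylamino for an alkoxy chain, and a step that the two limits leave unreadable from compound 1 to compound 2 only shortens the chain, yet all three are unreadable since their ends sit at the limit of > 20000 nM in this assay, at which 2 of the 3 values shown sit, or (the limit of > 24000 nM in this assay, at which 1 of the 3 values shown sits). No step beyond the scatter is therefore expected in this assay for compound 4. Compound 4 is expected to give about 20000 nM, between 10000 nM and 40000 nM, most likely reported once more as a limit. The expected step is an at least 1.2-fold lower number from compound 3 to compound 4 (0.07 log units; that floor lies within the scatter).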

Compound 4, half-maximal cytotoxic concentration: > 20000 nM
Compound 4: no number, only a limit (the forecaster's own chance of this, stated with the estimate: 85%); the middle value lies on the limit itself.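

Compound 4 also gives only a limit, so no step linking it to compound 1, compound 2 or compound 3 can be read in this assay: the limit of > 20000 nM in this assay, at which 3 of the 4 values shown sit.

The compounds shown leave open what concentration of any of them is half-maximally cytotoxic, and whether exchanging these groups on the shared core changes that concentration.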